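The source may hold more compounds than are shown below. What is called first, only, known or untested is meant among the compounds shown, and "the series" means these compounds.

In a physicochemical assay for solubility, with a stated time of 24 h (on this read-out higher numbers stand for higher solubility and lower numbers for lower solubility), compound 3 `C[C@@H](Oc1cc2onc(CCC(=O)O)c2cc1Cl)c1ccc(Cl)cn1` gives > 620 ug/mL, which is a limit and not a number. Compound 1 `Cc1ccc([C@@H](C)Oc2cc3onc(CCC(=O)O)c3cc2Cl)nc1` gives > 860 ug/mL, also a limit. Compound 2 `Cc1ccc([C@@H](C)Oc2cc3onc(CCC(=O)O)c3cc2Cl)nn1` gives 230 ug/mL, a measured number.

Compound 4 `C[C@@H](Oc1cc2onc(CCC(=O)O)c2cc1Cl)c1ccccn1` differs from compound 3 by hydrogen in place of chloro on an aromatic carbon, para to a large group, so that 5-chloropyridin-2-yl becomes pyridin-2-yl.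

The nearest measured change is chloro in place of methyl on an aromatic carbon, a step that the two limits leave unreadable from compound 1 to compound 3, and its size cannot be read. The two readable steps, an at least 3.7-fold lower number from compound 1 to compound 2 (0.57 log units; beyond the scatter) and an at least 2.6-fold higher number from compound 2 to compound 3 (0.43 log units; beyond the scatter), are both beyond the scatter, but both exchange the 6-methylpyridazin-3-yl group of compound 2 and so bear on the present change only loosely. With the step that the two limits leave unreadable from compound 1 to compound 3 unreadable, no step beyond the scatter is expected in this assay for the removal of chloro.

The expected step is a step that the limit leaves unreadable from compound 3 to compound 4.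

For compound 4 the estimate is 800 ug/mL, with an expected range of 350 ug/mL to 1500 ug/mL.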

Compound 4, solubility: > 7440 ug/mL
Compound 4 ended at the assay's limit (the forecaster's own chance of this, stated with the estimate: 55%); at least 9.3-fold (0.96 log units) between middle value and limit.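

In this assay compound 4 gives > 7440 ug/mL, which is a limit and not a number. With hydrogen on this aromatic carbon, para to a large group, the pyridin-2-yl compound ends at a limit, as compound 1 with methyl and compound 3 with chloro do, so neither of those two groups is needed at this place for that outcome. Pyridin-2-yl in place of 6-methylpyridazin-3-yl gives an at least 32-fold higher number from compound 2 to compound 4 (1.50 log units; beyond the scatter), a large step that stands beyond the scatter.

All steps among compound 1, compound 3 and compound 4 join two limits and cannot be read, so hydrogen, chloro and methyl at this carbon remain unranked. Also open, on these data alone, are how an amine or a methoxy group at this carbon would read, and whether a pyridazin-3-yl group without its methyl would stay near compound 2 or move towards compound 4.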